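Swapping one group of compound 2 for acetyl

The source may report more compounds than this note shows. Statements on the series, on what has been measured and on what is new or still open speak of the compounds shown alone.

Compound 1 `C=C(C)n1c(=O)n(Cc2nc3cc(C(=N)N)ccc3n2CCC(C)C)c2ccccc21`: 10800 nM
Compound 2 `C=C(C)n1c(=O)n(Cc2nc3cc(/C(N)=N\O)ccc3n2CCC(C)C)c2ccccc21`: 3470 nM
Compound 3 `CC(C)CCn1c(Cn2c(=O)n(CC(=O)OC(C)(C)C)c3ccccc32)nc2cc(/C(N)=N\O)ccc21`: 19800 nM

In an ADME assay on HEp-2 cells (Homo sapiens) for cytotoxicity (on this read-out higher numbers stand for lower toxicity in this test and lower numbers for higher toxicity in this test), compound 2 has the lowest of the three numbers, 3470 nM. Compound 4 `C=C(C)n1c(=O)n(Cc2nc3cc(C(C)=O)ccc3n2CCC(C)C)c2ccccc21` differs from it in one place: a group of 3 heavy atoms (2 carbon, 1 oxygen; no ring) in place of a group of 4 heavy atoms (1 carbon, 2 nitrogen, 1 oxygen; no ring), on an aromatic carbon. The closest guide is the modest change at that same place, a 3.1-fold lower number from compound 1 to compound 2 (0.49 log units; beyond the scatter). Elsewhere in the molecule, the change a 5.7-fold higher number from compound 2 to compound 3 (0.76 log units; beyond the scatter) is also modest, but it bears less directly. Among the compounds with values here, no measured compound carries acetyl, so the direction is uncertain. Compound 1, which also lacks the group that leaves, stands higher at 10800 nM, so a modest rise is expected. The expected change is a 2.0-fold higher number from compound 2 to compound 4 (0.30 log units; within the scatter). For compound 4 the estimated value is 7000 nM, with an expected range of 2000 nM to 25000 nM.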

Compound 4, half-maximal cytotoxic concentration: 740 nM
Compound 4: the middle estimate sits 9.5-fold (0.98 log units) above what was measured, outside the stated range (below it).
By their numbers in this assay, from the lowest: compound 4; then compound 2; then compounds 1 and 3 (each within the scatter of the next).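

Acetyl on this aromatic carbon gives the lowest number so far in this assay, with a 4.7-fold lower number from compound 2 to compound 4 (0.67 log units; beyond the scatter) and a 15-fold lower number from compound 1 to compound 4 (1.16 log units; beyond the scatter) in the same read-out. The group at this one place can therefore move the number further than the earlier pair showed, and the new group lies on the side of higher toxicity in this test. Nothing measured here explains the order of these three groups.

From the compounds shown here alone, how an amine or a carboxylic acid on this carbon would compare remains open. So does whether acetyl would lower the number equally with (tert-butoxycarbonyl)methyl in place of 1-methylethenyl on the aromatic nitrogen.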